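This account rests on a few compounds, and the source may have more. Where it says the series, first, only, none or still open, it means among the compounds named here.

In a functional assay on HepG2 cells (Homo sapiens) for cytotoxicity, read by MTT assay, with a stated time of 72 h (on this read-out lower numbers stand for stronger inhibition and higher numbers for weaker inhibition), two compounds built on a shared core have been measured. Compound 1 (`CNC(=O)c1cc(Oc2ccc(C3=NNC(c4ccc([N+](=O)[O-])cc4)C3)cc2)ccn1`) gives > 50000 nM, which is a limit of the assay and not a number. For the measured compounds named here, compound 2 (`CNC(=O)c1cc(Oc2ccc(C3=NNC(c4ccccc4)C3)cc2)ccn1`) gives 1500 nM, the only actual number so far. Its standing can be judged against nothing but the result for compound 1. Compound 3 (`CNC(=O)c1cc(Oc2ccc(C3=NNC(c4cccc(Cl)c4Cl)C3)cc2)ccn1`) carries 2,3-dichlorophenyl in place of phenyl on a saturated ring carbon. Going by the values given here, one measured step bears on this change, and only loosely: an at least 33-fold lower number from compound 1 to compound 2 (1.52 log units; beyond the scatter), with hydrogen in place of nitro on an aromatic carbon of that same ring. From the compounds shown here alone, that step is large, and its full size stays open because of the limit of > 50000 nM in this assay, at which 1 of the 2 values shown sits. It involves a different group, so it offers a direction rather than a size. A modest move towards a higher number in this assay is therefore expected, far smaller than the step seen with compound 1. The expected change is a 2.0-fold higher number from compound 2 to compound 3 (0.30 log units; within the scatter). For compound 3 the estimated value is 3000 nM, with an expected range from 600 nM to 20000 nM.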

Compound 3, half-maximal inhibitory concentration: 4990 nM
Compound 3: middle estimate off by 1.7-fold (0.22 log units), on the low side; low and high end bracket the measured number.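

In this assay, this position on a saturated ring carbon now has a direct reading for a substituted phenyl set against plain phenyl, where the earlier step had only compared nitro with hydrogen: 2,3-dichlorophenyl in place of phenyl gives a 3.3-fold higher number from compound 2 to compound 3 (0.52 log units; beyond the scatter), a modest step, so the two chlorine atoms cost some activity without abolishing it. The two substituted phenyl groups do not behave alike, for 2,3-dichlorophenyl in place of 4-nitrophenyl gives an at least 10-fold lower number from compound 1 to compound 3 (1.00 log units; beyond the scatter), and of the three compounds phenyl itself carries the lowest number, with both substituted groups lying above it by steps beyond the scatter. From the compounds shown here alone, the full size of that second step stays open, since the value for compound 1 is a limit and not a number: the limit of > 50000 nM in this assay, at which 1 of the 3 values shown sits.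

The compounds shown leave open whether one chlorine on the phenyl would give the same shift as two, and whether the placing of the chlorine atoms matters at all. They also leave open what a methoxy group, an amine or a carboxylic acid on this phenyl would do, and whether any group here can bring the number below that of compound 2.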